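Cyclopentyl to 2,3-difluorophenyl on the imidazole side chain

A few compounds are considered here, and "the series" means these few. Any claim that something is new, unique, unknown or untested is made for them only; others in the source may bear on it.

Measured compounds:
compound 1 `O=C(O)c1ccccc1-c1ccc(CCc2ncc(CC3CCCC3)[nH]2)cc1` gives 7.9 nM
compound 2 `COc1ccc(Cc2cnc(CCc3ccc(-c4ccccc4C(=O)O)cc3)[nH]2)cc1` gives 513 nM
compound 3 `O=C(O)c1ccccc1-c1ccc(CCc2ncc(CC3CC3)[nH]2)cc1` gives 72 nM

All three share one core and differ only in the group on a saturated chain carbon bound to an aromatic carbon. In an in vitro functional assay on cells for agonist activity at Bombesin receptor subtype-3 (Mus musculus), read by luminescence and calcium flux (a lower number here means that less compound is needed, a higher number that more compound is needed for the effect), compound 1 stands lowest of the three; the nearest to it is compound 3, a 9.1-fold higher number from compound 1 to compound 3 (0.96 log units; beyond the scatter), and the furthest is compound 2, a 65-fold higher number from compound 1 to compound 2 (1.81 log units; beyond the scatter). Between the two weaker compounds, a 7.1-fold lower number from compound 2 to compound 3 (0.85 log units; beyond the scatter).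

Compound 4 `O=C(O)c1ccccc1-c1ccc(CCc2ncc(Cc3cccc(F)c3F)[nH]2)cc1` is not yet measured. Its change from compound 1 is 2,3-difluorophenyl in place of cyclopentyl on a saturated chain carbon bound to an aromatic carbon. For the measured compounds named here, two measured steps bear on it. Replacing cyclopentyl by the aryl group 4-methoxyphenyl cost a large step, a 65-fold higher number from compound 1 to compound 2 (1.81 log units; beyond the scatter); shrinking the saturated ring to cyclopropyl cost a modest step, a 9.1-fold higher number from compound 1 to compound 3 (0.96 log units; beyond the scatter). Compound 4 brings in an aromatic ring, as compound 2 does, but without the methoxy group and with two fluorines, so the precedent of compound 2 may overstate the loss. A higher number than compound 1 is expected, and the step is estimated as a 13-fold higher number from compound 1 to compound 4 (1.10 log units; beyond the scatter), probably beyond the scatter. For compound 4 the estimate is 100 nM, with a range from 20 nM to 600 nM.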

Compound 4, half-maximal effective concentration: 8 nM
Estimate against measurement, compound 4: 13-fold (1.10 log units) above; measured number outside the range, below it.
By their numbers in this assay, from the lowest: compounds 1 and 4 (each within the scatter of the next); then compound 3; then compound 2.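

Notes on the group on a saturated chain carbon bound to an aromatic carbon: in this assay, an aromatic ring here does not by itself raise the number, since 2,3-difluorophenyl in place of cyclopentyl gives a 1.0-fold higher number from compound 1 to compound 4 (0.01 log units; within the scatter) and leaves the two compounds indistinguishable. The large cost of 4-methoxyphenyl therefore cannot be read as a cost of all aryl groups at this place, as the exchange of the two aryl groups shows with a 64-fold lower number from compound 2 to compound 4 (1.81 log units; beyond the scatter) between them. Ring type alone does not set the number either: the saturated cyclopropyl group of compound 3 stands apart from the aromatic group of compound 4, with a 9.0-fold lower number from compound 3 to compound 4 (0.95 log units; beyond the scatter), while among the aromatic groups compound 2 goes the other way. Nothing available here bears on the cause of these differences.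

Still open, as far as these compounds go, is whether unsubstituted phenyl would sit with compound 4 or with compound 2, which would help separate the contribution of the two fluorines from that of the methoxy group. From the compounds shown here alone, the response to cyclohexyl, or to a longer chain carrying the 2,3-difluorophenyl group, also remains unknown.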